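Shortening a phenyl chain at the assay limit

The source may report more compounds than this note shows. Statements on the series, on what has been measured and on what is new or still open speak of the compounds shown alone.

In a functional assay on NCI-H630 cells (Homo sapiens) for cytotoxicity, read by sulforhodamine B assay, with a stated time of 5 days (on this read-out lower numbers stand for stronger inhibition and higher numbers for weaker inhibition), compound 2 (`O=C(CCCc1ccccc1)CC(=O)N[C@H]1CCOC1=O`) reads > 100000 nM as a limit, not a number. Compound 1 (`O=C(CCCCc1ccccc1)CC(=O)N[C@H]1CCOC1=O`) gives > 100000 nM as a limit too. Compound 3 (`O=C(CCCCCCCCc1ccccc1)N[C@H]1CCOC1=O`) also gives > 100000 nM as a limit. The picture so far is the limit of > 100000 nM in this assay, at which 3 of the 3 values shown sit, and offers no measured number. Compound 4 (`O=C(CCc1ccccc1)CC(=O)N[C@H]1CCOC1=O`) differs from compound 2 as follows: phenyl in place of benzyl on a saturated chain carbon, two bonds along the chain from a carbonyl carbon. The closest measured change is a step that the two limits leave unreadable from compound 1 to compound 2 and so gives no size to carry over. The expected change, a number no higher from compound 2 to compound 4 (the limit leaves the size open), is estimated to stay within the scatter, with no direction favoured. Compound 4 is expected near 100000 nM, with an estimated range from 40000 nM to 200000 nM, and will most likely be reported only as a limit.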

Compound 4, half-maximal inhibitory concentration: > 100000 nM
Compound 4 ended at the assay's limit; the forecaster's own chance of this, stated with the estimate: 85%; the middle value lies on the limit itself.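

Among these compounds, compound 2 and compound 4 both end as limits, not numbers, so no step between them can be read: the limit of > 100000 nM in this assay, at which 4 of the 4 values shown sit. As far as these compounds go, what stays open is whether any change to the chain would give a measurable number in this assay.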